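Two Measured Esters and One Expected Value

The source may hold more compounds than are shown below. What is called first, only, known or untested is meant among the compounds shown, and "the series" means these compounds.

Compound 1 `COC(=O)/C(=C\c1ccc(OC(=O)c2ccc(OC)cc2)cc1)Sc1ccnc2cc(Cl)ccc12` gives 63500 nM in an ADME assay on cells (Lymphocyte, Homo sapiens) for cytotoxicity, read by MTT assay, with a stated time of 48 h; a higher number here means a weaker inhibitor, a lower number a stronger inhibitor.
Compound 2 `COC(=O)/C(=C\c1ccc(OC(=O)c2cc(OC)cc(OC)c2)cc1)Sc1ccnc2cc(Cl)ccc12` gives 84100 nM in this assay.

Going by the values given here, these are the only two numbers known, and compound 1 and compound 2 lie within the usual scatter of each other: the step in this assay was a 1.3-fold higher number from compound 1 to compound 2 (0.12 log units; within the scatter), for 3,5-dimethoxyphenyl in place of 4-methoxyphenyl on a carbonyl carbon. Compound 3 `COC(=O)/C(=C\c1ccc(OC(=O)c2cc(OC)c(OC)cc2OC)cc1)Sc1ccnc2cc(Cl)ccc12` has not been measured. It differs from compound 1 as follows: 2,4,5-trimethoxyphenyl in place of 4-methoxyphenyl on a carbonyl carbon. Among the compounds with values here, the only measured step that bears on this change is the one from compound 1 to compound 2, which also added methoxy groups to the same phenyl ring and stayed within the scatter. On that basis no step beyond the scatter is expected in this assay for compound 3, with at most a slight drift toward a higher number. For compound 3 the expected value is 75000 nM, with a range from 35000 nM to 160000 nM. That estimate corresponds to an expected step of a 1.2-fold higher number from compound 1 to compound 3 (0.07 log units; within the scatter).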

Compound 3, half-maximal inhibitory concentration: 52500 nM
Estimate against measurement, compound 3: 1.4-fold (0.15 log units) above; low and high end bracket the measured number.
By their numbers in this assay, from the lowest: compounds 3, 1 and 2 (each within the scatter of the next).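

In this assay, putting 2,4,5-trimethoxyphenyl on the carbonyl carbon gives a 1.2-fold lower number from compound 1 to compound 3 (0.08 log units; within the scatter), and the change from 3,5-dimethoxyphenyl gives a 1.6-fold lower number from compound 2 to compound 3 (0.20 log units; within the scatter). The 4-methoxyphenyl, 3,5-dimethoxyphenyl and 2,4,5-trimethoxyphenyl groups thus stand at this place with no step beyond the scatter among them, which now holds for a third substitution pattern and for a group with 3 hydrogen-bond acceptors rather than 1. No measurement shown explains why these values stay so close.

As far as these compounds go, all three compounds carry only methoxy groups on this phenyl ring, so whether an amine, a carboxylic acid or a longer alkoxy chain there would give a step beyond the scatter stays open. Also open, from the compounds shown here alone, is what an amide nitrogen would do in place of the oxygen next to a carbonyl group, which all three share.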